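A few compounds are considered here, and "the series" means these few. Any claim that something is new, unique, unknown or untested is made for them only; others in the source may bear on it.

Measured so far:
Compound 1, `CCCC(=O)Nc1c(C(O)(C(F)(F)F)C(F)(F)F)ccc2ccccc12`: in an assay on LtK cells with ATP-sensitive inward rectifier potassium channel 11 (Homo sapiens) as the target (a lower number here means that less compound is needed, a higher number that more compound is needed for the effect), compound 1 gives 131 nM.
Compound 2, `CC(C)OC(=O)Nc1c(C(O)(C(F)(F)F)C(F)(F)F)ccc2ccccc12`: compound 2 gives 1160 nM.
Compound 3, `O=C(Nc1c(C(O)(C(F)(F)F)C(F)(F)F)ccc2ccccc12)c1ccc(Cl)cc1`: compound 3 gives 570 nM.

Compound 2 stands at the highest number of the three, with compound 3 nearest (a 2.0-fold lower number from compound 2 to compound 3 (0.31 log units; beyond the scatter)) and compound 1 furthest (an 8.9-fold higher number from compound 1 to compound 2 (0.95 log units; beyond the scatter)). Compound 4, `O=C(Nc1c(C(O)(C(F)(F)F)C(F)(F)F)ccc2ccccc12)c1cccc(Cl)c1Cl`, differs from compound 2 by 2,3-dichlorophenyl in place of isopropoxy on a carbonyl carbon. The step from compound 2 to compound 3 is the one that bears most directly on this change, since it too places a chlorinated phenyl ring on the carbonyl carbon; the step from compound 1 to compound 3, a 4.4-fold higher number from compound 1 to compound 3 (0.64 log units; beyond the scatter), shows that such an aryl group still sits well above compound 1. A modest lower number is therefore expected for compound 4, a 2.3-fold lower number from compound 2 to compound 4 (0.37 log units; beyond the scatter). The estimate for compound 4 is 500 nM, in the range 200 nM to 1300 nM.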

Compound 4, half-maximal effective concentration: > 10000 nM
Compound 4 gave a limit, no number; the forecaster's own chance of this, stated with the estimate: 3%; middle value at least 20-fold (1.30 log units) from the limit.
By their numbers in this assay, from the lowest: compound 1; then compound 3; then compound 2. At a limit, above all of these: compound 4.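

Compound 4 gives a limit, not a number: the limit of > 10000 nM in this assay, at which 1 of the 4 values shown sits. An aryl group on this carbonyl carbon is therefore not enough to keep a measurable value, and the pattern of chlorines on the phenyl ring matters, with an at least 17-fold higher number from compound 3 to compound 4 (1.24 log units; beyond the scatter). The 2,3-dichlorophenyl group also stands well beyond isopropoxy, with an at least 8.6-fold higher number from compound 2 to compound 4 (0.93 log units; beyond the scatter), and propyl, with an at least 76-fold higher number from compound 1 to compound 4 (1.88 log units; beyond the scatter).

From the compounds shown here alone, how far compound 4 lies past its limit remains unknown. Also open, going by these compounds, is how an unsubstituted phenyl, a longer alkyl chain or an amine would read on this carbonyl carbon.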